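Furan-to-chlorophenyl swap on the cyanoacrylamide series

This account rests on a few compounds, and the source may have more. Where it says the series, first, only, none or still open, it means among the compounds named here.

Measured so far, in a functional assay on NCI-H460 cells (Homo sapiens) for inhibition, read by MTT assay, with a stated time of 72 h; a lower number here means a stronger inhibitor of growth, a higher number a weaker inhibitor of growth:
compound 1 `COc1ccc(CNC(=O)/C(C#N)=C/c2ccc(Br)o2)cc1`: 16000 nM
compound 2 `COc1ccc(CNC(=O)/C(C#N)=C/c2cc(Br)co2)cc1`: value reported only as a limit, > 100000 nM
compound 3 `COc1ccc(CNC(=O)/C(C#N)=C/c2ccoc2)cc1`: 8000 nM

Compound 3 gives the lowest number of the two numbers shown; compound 1 sits close to it, a 2.0-fold lower number from compound 1 to compound 3 (0.30 log units; within the scatter). Compound 2 reaches only the assay limit (the limit of > 100000 nM in this assay, at which 1 of the 3 values shown sits). Moving the bromine on the furan therefore matters: an at least 6.2-fold higher number from compound 1 to compound 2 (0.79 log units; beyond the scatter) and an at least 12-fold lower number from compound 2 to compound 3 (1.09 log units; beyond the scatter) are both beyond the scatter, while the loss of bromine itself, a 2.0-fold lower number from compound 1 to compound 3 (0.30 log units; within the scatter), stays within it.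

Compound 4 `COc1ccc(CNC(=O)/C(C#N)=C/c2ccc(Cl)cc2)cc1` differs from compound 3 by 4-chlorophenyl in place of furan-3-yl on a double-bonded chain carbon bound to a double-bonded chain carbon. Within the data shown here, none of the measured steps bears on this change: every step so far keeps a furan and alters only the bromine on it, whereas here the whole ring is exchanged for a six-membered carbon ring bearing chlorine. The steps show that a small change on this aryl group can shift this assay substantially, but they give no direction for a furan-to-phenyl exchange. The estimate for compound 4 is therefore set at the value of compound 3, with a wide range, and the expected step of no change at the digits printed from compound 3 to compound 4 (within the scatter) is within the scatter. Compound 4 is thus expected to give about 8000 nM in this assay, between 2000 nM and 40000 nM.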

Compound 4, concentration for 50% growth inhibition: 14000 nM
The estimate for compound 4 lay 1.8-fold (0.24 log units) below the measured number; low and high end bracket the measured number.
By their numbers in this assay, from the lowest: compounds 3, 4 and 1 (each within the scatter of the next). At a limit, above all of these: compound 2.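

In this assay, among these compounds, the first exchange of the whole ring shows that a furan is not needed at this place on a double-bonded chain carbon: a 1.8-fold higher number from compound 3 to compound 4 (0.24 log units; within the scatter), and a 1.1-fold lower number from compound 1 to compound 4 (0.06 log units; within the scatter). Among the compounds shown here, the larger 4-chlorophenyl, with its six-membered aromatic ring of carbon only, thus stands level with furan-3-yl and 5-bromofuran-2-yl, whereas an at least 7.1-fold lower number from compound 2 to compound 4 (0.85 log units; beyond the scatter), which makes 4-bromofuran-2-yl, so far, the only group of the four that departs from the others. Compound 2 alone remains without a number, and its value is only a limit: the limit of > 100000 nM in this assay, at which 1 of the 4 values shown sits.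

The compounds shown do not separate the contribution of the chlorine from that of the six-membered ring, and a plain phenyl would be needed to do so. As far as these compounds go, it also remains open whether an amine or a carboxylic acid in place of the chlorine on the 4-chlorophenyl ring would hold this level, or whether any change elsewhere on the shared core would shift it further.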